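The source may report more compounds than this note shows. Statements on the series, on what has been measured and on what is new or still open speak of the compounds shown alone.

Compound 1 `FC(F)(F)c1cccc(CNc2cc(C(F)(F)F)cc3[nH]ncc23)c1`: in an assay for inhibition of Indoleamine 2,3-dioxygenase 1 (Homo sapiens), with stated times of 10 min and 60 min (a lower number here means a stronger inhibitor, a higher number a weaker inhibitor), a limit only, > 100000 nM.
Compound 2 `Nc1cccc(CNc2cc(C(F)(F)F)cc3[nH]ncc23)c1`: in this assay a limit only, > 100000 nM.

Compound 2 stands at the limit of this assay, not at a number. For the measured compounds named here, the only measured step, a step that the two limits leave unreadable from compound 1 to compound 2, cannot be read, since both values sit at the limit (the limit of > 100000 nM in this assay, at which 2 of the 2 values shown sit). Compound 3 `FC(F)(F)c1cc(NCc2cccc(Br)c2)c2cn[nH]c2c1` differs from compound 2 by bromo in place of amino on an aromatic carbon. Going by the values given here, no measured step bears on this change, so the expected step, a step that the limit leaves unreadable from compound 2 to compound 3, is set at none beyond the scatter. Compound 3 is estimated at 150000 nM, range 30000 nM to 1000000 nM, most likely again reported only as a limit.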

Compound 3, half-maximal inhibitory concentration: > 100000 nM
Compound 3 gave a limit, no number; the forecaster's own chance of this, stated with the estimate: 80%; the middle value does not contradict the limit.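

No step among compound 1, compound 2 and compound 3 can be read, since all three values are limits: the limit of > 100000 nM in this assay, at which 3 of the 3 values shown sit.

The compounds shown leave open how trifluoromethyl, amino and bromo on this aromatic carbon rank against one another.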